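The source may report more compounds than this note shows. Statements on the series, on what has been measured and on what is new or still open speak of the compounds shown alone.

Series notes. In an assay for inhibition of kynurenine 3-monooxygenase (Homo sapiens), read by mass spectrometry, with a stated time of 1 h (on this read-out lower numbers stand for stronger inhibition and higher numbers for weaker inhibition), compound 1, `Cc1ccc([C@@H](C)Oc2cc3onc(CCC(=O)O)c3cc2Cl)nc1`, gives 3.16 nM. Compound 2, `O=C(O)CCn1c(=O)oc2cc(OCc3ccccn3)c(Cl)cc21`, which carries a different core and a pyridinylmethyl ether in place of the branched chain, gives 3.16 nM in this assay. Compound 3, `C[C@@H](Oc1cc2oc(=O)n(CCC(=O)O)c2cc1Cl)c1ccc(F)cn1`, is built on the same core as compound 2 but with the branched chain restored. In this assay compound 3 gives 2.51 nM. On these three numbers compound 1 stands level with compound 2 at the digits given, and the pair share the highest number of the set; compound 3 sits nearest and furthest at once, with a number only slightly lower than that of compound 1, and the whole spread lies within the usual scatter of this assay. Among the compounds with values here, no step between measured compounds that differ in one place is available.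

Compound 4, `Cc1ccc([C@@H](C)Oc2cc3onc(CCC(=O)O)c3cc2Cl)nn1`, is not yet measured. It differs from compound 1 by 6-methylpyridazin-3-yl in place of 5-methylpyridin-2-yl on a saturated chain carbon bound to an oxygen on an aromatic ring and a saturated chain carbon. Since compounds 1, 2 and 3 all sit at the same level regardless of core or ether, no step beyond the scatter is expected here either; the step of a 1.3-fold higher number from compound 1 to compound 4 (0.10 log units; within the scatter) is estimated to stay within the scatter. Compound 4 is expected to give about 4 nM in this assay, with a likely range from 1.5 nM to 12 nM.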

Compound 4, half-maximal inhibitory concentration in the kynurenine 3-monooxygenase assay: 2 nM
The estimate for compound 4 lay 2.0-fold (0.30 log units) above the measured number; the range from low to high includes it.
By their numbers in the kynurenine 3-monooxygenase assay, from the lowest: compounds 4, 3, 1 and 2 (each within the scatter of the next).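

Within the data shown here, in the kynurenine 3-monooxygenase assay, this is the first change confined to one place, and 6-methylpyridazin-3-yl in place of 5-methylpyridin-2-yl on a saturated chain carbon bound to an oxygen on an aromatic ring and a saturated chain carbon gives a 1.6-fold lower number from compound 1 to compound 4 (0.20 log units; within the scatter), so a ring with 2 hetero atoms and 2 hydrogen-bond acceptors is tolerated here as well as the ring with 1 of each. In a physicochemical assay for pharmacokinetics, at pH 6 (on this read-out lower numbers stand for a shorter-lived compound and higher numbers for a longer-lived compound), compound 1 gives > 1000 h, which is a limit of the assay. In the physicochemical assay compound 4 gives > 1000 h, which is likewise a limit of the assay.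

The step between these two compounds cannot be read in this read-out, because both values stand at one limit: the limit of > 1000 h in the physicochemical assay, at which 2 of the 2 values shown sit. Whether an amine or an unsubstituted phenyl ring in place of these rings, at the same place on the shared core, would keep the number in the kynurenine 3-monooxygenase assay within the scatter remains open, since the compounds shown cover only these two methyl-bearing aromatic rings at this place.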